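Methyl removal on the aryl ring of compound 2

This account rests on a few compounds, and the source may have more. Where it says the series, first, only, none or still open, it means among the compounds named here.

Of the compounds shown here, two of the shared core carry numbers so far. Compound 1 `CCCn1c(-c2ccccc2)nc2c(NC3CCCCC3)ncnc21` gives 27 nM in an assay on CHO cells for displacement of a labelled ligand from adenosine receptor A1 (Homo sapiens), read by scintillation counting, with a stated time of 3 h; a lower number here means a stronger inhibitor, a higher number a weaker inhibitor. Compound 2 `Cc1ccc(-c2nc3c(NC4CCCC4)ncnc3n2C)cc1` gives 8 nM in this assay, the lowest of the two numbers; its nearest neighbour is compound 1, whose number is higher by a margin beyond the scatter. For the measured compounds named here, compound 1 and compound 2 differ in more than one place, so no single step is drawn between them. Compound 3 `Cn1c(-c2ccccc2)nc2c(NC3CCCC3)ncnc21` is not yet measured in this assay. It differs from compound 2 by hydrogen in place of methyl on an aromatic carbon. Going by the values given here, no measured pair isolates this change. The step is expected to be small: either none beyond the scatter or a modest rise in the number. Compound 3 is therefore estimated at 12 nM, with a range of 4 nM to 40 nM. That estimate means an expected step of a 1.5-fold higher number from compound 2 to compound 3 (0.18 log units; within the scatter).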

Compound 3, inhibition constant: 2.8 nM
For compound 3 the middle estimate is 4.3-fold (0.63 log units) above the measured one, outside the stated range (below it).
By their numbers in this assay, from the lowest: compound 3; then compound 2; then compound 1.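

In this assay, the change from 4-methylphenyl to phenyl gives a 2.9-fold lower number from compound 2 to compound 3 (0.46 log units; beyond the scatter). For the compounds shown here, this is the first pair to isolate this position, and it shows that the methyl on this aromatic carbon, para to a large group, is not required for a low number here: hydrogen gives the lower one. The loss of a single carbon, with no ring, hydrogen-bond donor, acceptor or net charge involved, is enough to move the number beyond the scatter, and no measurement at hand bears on the reason.

On these data alone, with only methyl and hydrogen compared at this position, it remains open how a chlorine, a methoxy group or a carboxylic acid there would behave. As far as these compounds go, it is also open whether the same step would appear on compound 1, which differs from compound 3 in more than this position.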